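Methyl on the Saturated Ring and Cytotoxicity

This account rests on a few compounds, and the source may have more. Where it says the series, first, only, none or still open, it means among the compounds named here.

Compound 1, `CC1(COc2cccc(-c3ccc(F)cc3)n2)CCn2cc([N+](=O)[O-])nc2O1`, gives a limit of > 64000 nM in an ADME assay on MRC5 cells (Homo sapiens) for cytotoxicity, read by resazurin assay, with a stated time of 72 h; on this read-out lower numbers stand for stronger inhibition and higher numbers for weaker inhibition.
Compound 2, `O=[N+]([O-])c1cn2c(n1)OC(COc1cccc(-c3ccc(F)cc3)n1)CC2`, gives 59000 nM in this assay.
Compound 3, `O=[N+]([O-])c1cn2c(n1)OC(COc1ccc(-c3ccc(F)cc3F)cn1)CC2`, gives a limit of > 64000 nM in this assay.

In this set, two of the three values shown are limits of the assay rather than numbers, as the limit of > 64000 nM in this assay, at which 2 of the 3 values shown sit, states. Among the compounds with values here, the one counted step runs from compound 2 to compound 1: an at least 1.0-fold higher number from compound 2 to compound 1 (0.03 log units; that floor lies within the scatter), where the change is methyl in place of hydrogen on a saturated ring carbon. The difference between the core of compound 2 and the core of compound 3 is not broken down here.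

Compound 4, `CC1(COc2ccc(-c3ccc(F)cc3F)cn2)CCn2cc([N+](=O)[O-])nc2O1`, is not yet measured. Within the data shown here, it differs from compound 3 by methyl in place of hydrogen on a saturated ring carbon, the same change as the one from compound 2 to compound 1, at a place described in the same words. Compound 4 is expected to show a step that the limit leaves unreadable from compound 3 to compound 4 in this assay; that expectation rests on compound 2 and compound 1 with an at least 1.0-fold higher number from compound 2 to compound 1 (0.03 log units; that floor lies within the scatter) and on compound 3 with > 64000 nM. Compound 4 is therefore estimated at 80000 nM, between 45000 nM and 160000 nM, most likely reported again only as a limit.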

Compound 4, half-maximal inhibitory concentration: > 64000 nM
Compound 4 ended at the assay's limit; the forecaster's own chance of this, stated with the estimate: 75%; the middle value lies beyond the limit too.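

Compound 3 and compound 4 both stand as limits of the assay rather than as numbers, so no new step can be read between them: the limit of > 64000 nM in this assay, at which 3 of the 4 values shown sit.

The compounds shown leave open whether methyl in place of hydrogen on a saturated ring carbon shifts the number in this assay at all, on either the core of compound 2 or the core of compound 3.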